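Trimming a propyl chain on two related cores

The source may report more compounds than this note shows. Statements on the series, on what has been measured and on what is new or still open speak of the compounds shown alone.

Four small heteroaromatic compounds are compared here. Compound 1 `CCCc1ncc2cnnc(S)n12` carries a thiol and a propyl chain, while compound 3 `CCCc1ncn2c(Nc3cc[nH]n3)nccc12` carries a pyrazolylamino group and the same propyl chain; how the two cores differ is not broken down here. Compound 2 `Cc1ncn2c(Nc3cc[nH]n3)nccc12` is compound 3 with the chain cut back, and compound 4 `Cc1ncc2cnnc(S)n12` is compound 1 with the same cut, not yet measured.

In a functional assay for inhibition, with Homo sapiens as the target (on this read-out higher numbers stand for weaker inhibition and lower numbers for stronger inhibition), compound 2 gives 57000 nM. For compound 3 the result is only a limit of this assay, > 48000 nM. For compound 1 the result is likewise only a limit, > 48000 nM. The step that the limit leaves unreadable from compound 3 to compound 2 therefore cannot be read, because of the limit of > 48000 nM in this assay, at which 2 of the 3 values shown sit.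

The change is hydrogen in place of ethyl on a saturated chain carbon bound to an aromatic carbon, and the same change in the same place is hydrogen in place of ethyl on a saturated chain carbon bound to an aromatic carbon. With one end unreadable, the step is expected to stay small, a step that the limit leaves unreadable from compound 1 to compound 4, so compound 4 is estimated at 60000 nM, most likely between 30000 nM and 200000 nM.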

Compound 4, half-maximal inhibitory concentration: > 48000 nM
Compound 4 was reported as a limit (the forecaster's own chance of this, stated with the estimate: 65%); the middle value does not contradict the limit.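

No step can be read between compound 1 and compound 4, because both results are limits rather than numbers: the limit of > 48000 nM in this assay, at which 3 of the 4 values shown sit.

On these data alone, whether cutting propyl to methyl changes inhibition in this assay on either core stays open, and so does whether any of these four compounds truly differs from the others.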